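A few compounds are considered here, and "the series" means these few. Any claim that something is new, unique, unknown or untested is made for them only; others in the source may bear on it.

Compound 1 `COc1cc2c(Oc3ccc(NC(=O)c4cc(-c5ccccc5)nc5ccccc45)cc3F)ccnc2cc1OCCCN1CCCCC1` gives 290 nM in a functional assay on SMMC-7721 cells (Homo sapiens) for cytotoxicity, read by MTT assay, with a stated time of 72 h; a higher number here means a weaker inhibitor, a lower number a stronger inhibitor. Compound 2 `COc1cc2c(Oc3ccc(NC(=O)c4cc(-c5cccc(Cl)c5)nc5ccccc45)cc3F)ccnc2cc1OCCCN1CCCCC1` gives 30 nM in this assay, and compound 3 `COc1cc2c(Oc3ccc(NC(=O)c4cc(-c5ccccc5)nc5ccccc45)cc3F)ccnc2cc1OCCCN1CCC(C)CC1` gives 160 nM. Among these three numbers, compound 3 stands second highest: compound 1 sits within the scatter of it, while compound 2 lies clearly below it. Compound 4 `COc1cc2c(Oc3ccc(NC(=O)c4cc(-c5ccc(C)cc5)nc5ccccc45)cc3F)ccnc2cc1OCCCN1CCC(C)CC1` has not yet been measured. It differs from compound 3 in one place: methyl in place of hydrogen on an aromatic carbon. Two measured steps are known. The step of a 1.8-fold lower number from compound 1 to compound 3 (0.26 log units; within the scatter) concerns a different part of the molecule and says little here. More telling is a 9.7-fold lower number from compound 1 to compound 2 (0.99 log units; beyond the scatter), where a chloro added to the same phenyl ring lowered the number well beyond the scatter. A methyl is a different group from a chloro, so a smaller step is expected, still in the lowering direction. For compound 4 the expected step is a 2.0-fold lower number from compound 3 to compound 4 (0.30 log units; within the scatter). The estimate for compound 4 is 80 nM, with a range from 25 nM to 250 nM.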

Compound 4, half-maximal inhibitory concentration: 1260 nM
Compound 4: the middle estimate sits 16-fold (1.20 log units) below what was measured; the measured number lies above the stated range.
By their numbers in this assay, from the lowest: compound 2; then compounds 3 and 1 (each within the scatter of the next); then compound 4.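

Putting a methyl on the phenyl ring brought a 7.9-fold higher number from compound 3 to compound 4 (0.90 log units; beyond the scatter) and not the fall seen with a chloro on that same ring, which gave a 9.7-fold lower number from compound 1 to compound 2 (0.99 log units; beyond the scatter) in an otherwise matched pair. So this ring does not answer every added group in one direction: a single added carbon, para to a large group, is enough to move the number beyond the scatter. Nothing measured here says why the two steps point opposite ways.

The two steps differ in the group, in the ring carbon that carries it and in the methyl on the saturated ring, and the compounds shown cannot separate these three. Still open, going by these compounds, is how this ring carbon would respond to a chloro, a methoxy or an amine, and how a methyl would behave on the ring carbon that carries the chloro in compound 2.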